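The source may report more compounds than this note shows. Statements on the series, on what has been measured and on what is new or still open speak of the compounds shown alone.

Measured so far:
- Compound 1 `Cc1ccc2nc(-c3cccc4ccccc34)[nH]c(=O)c2c1`: > 50000 nM
- Compound 2 `O=c1[nH]c(-c2cccc3ccccc23)nc2ccc(N3CCCCC3)cc12`: 2240 nM

In a functional assay on HCT-15 cells (Homo sapiens) for cytotoxicity, read by MTT assay, with a stated time of 2 days (a higher number here means a weaker inhibitor, a lower number a stronger inhibitor), the reading for compound 1, > 50000 nM, is a limit and not a number. For the measured compounds named here, compound 2, with 2240 nM, therefore holds the only actual number so far. Compound 3 `CCN(CC)c1ccc2nc(-c3cccc4ccccc34)[nH]c(=O)c2c1` carries diethylamino in place of piperidin-1-yl on an aromatic carbon. Going by the values given here, the one step that bears on this is large: an at least 22-fold lower number from compound 1 to compound 2 (1.34 log units; beyond the scatter). It compares piperidin-1-yl with methyl, not with diethylamino, so no change beyond the scatter is expected in this assay. The estimated step is a 1.1-fold higher number from compound 2 to compound 3 (0.05 log units; within the scatter). For compound 3 the expected value is 2500 nM, with an estimated range of 1000 nM to 6500 nM.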

Compound 3, half-maximal inhibitory concentration: 3210 nM
Beside the measured number, compound 3's estimate is 1.3-fold (0.11 log units) below it, within the range that was stated.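

In this assay, opening the ring leaves the reading within the scatter, with a 1.4-fold higher number from compound 2 to compound 3 (0.16 log units; within the scatter), so the closed ring of piperidin-1-yl is not needed at this position for this level of cytotoxicity. Diethylamino also keeps a large gain over methyl, with an at least 15-fold lower number from compound 1 to compound 3 (1.19 log units; beyond the scatter), so the gain seen with compound 2 is not tied to one amino group. The reading for compound 1 is a limit and not a number: the limit of > 50000 nM in this assay, at which 1 of the 3 values shown sits.

On these data alone, whether dimethylamino or a morpholin-4-yl ring would read the same at this position remains open. So does the effect of an amino group carrying longer chains, such as dibutylamino.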